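The compounds below may be only part of what the source reports. "The series", "measured", "known", "first", "only" and "open" are said of these compounds alone.

Measured compounds in a functional assay on HT-29 cells (Homo sapiens) for inhibition, read by MTT assay, with a stated time of 72 h; on this read-out higher numbers stand for weaker inhibition of growth and lower numbers for stronger inhibition of growth:
compound 1 `O=S(=O)(NCCCNCc1cccc2ccccc12)c1cc(C(F)(F)F)cc(C(F)(F)F)c1`, compound 1 gives 2600 nM
compound 2 `CC(C)(C)c1ccc(CNCCNS(=O)(=O)c2cc(C(F)(F)F)cc(C(F)(F)F)c2)cc1`, compound 2 gives 14000 nM
compound 3 `O=S(=O)(NCCNCc1ccc(-c2ccccc2)cc1)c1cc(C(F)(F)F)cc(C(F)(F)F)c1`, compound 3 gives 2700 nM

Compound 1 gives the lowest number of the three, yet compound 3 sits within the scatter of it; only compound 2 stands beyond the scatter, above both. Among the measured compounds shown here, the sole step between compounds differing in one place is a 5.2-fold lower number from compound 2 to compound 3 (0.71 log units; beyond the scatter).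

Compound 4 `O=S(=O)(NCCCNCC1COc2ccccc2O1)c1cc(C(F)(F)F)cc(C(F)(F)F)c1` is to be measured. Relative to compound 1 the change is 2,3-dihydro-1,4-benzodioxin-2-yl in place of naphthalen-1-yl on a saturated chain carbon bound to an amine nitrogen. For the measured compounds named here, no measured step touches this change; the one step known concerns a different part of the molecule. Compound 3 and compound 1 show that two different aromatic groups at this position give numbers within the scatter of each other, while compound 2 shows the position can matter. The expectation for compound 4 is therefore a step of a 1.5-fold higher number from compound 1 to compound 4 (0.19 log units; within the scatter) in this assay, with wide uncertainty. Compound 4 is estimated at 4000 nM, between 1500 nM and 12000 nM.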

Compound 4, concentration for 50% growth inhibition: 2200 nM
Compound 4: the middle estimate sits 1.8-fold (0.26 log units) above what was measured, and the stated range covers the measured number.
By their numbers in this assay, from the lowest: compounds 4, 1 and 3 (each within the scatter of the next); then compound 2.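

The step in this assay reads a 1.2-fold lower number from compound 1 to compound 4 (0.07 log units; within the scatter) and shows that, on a saturated chain carbon bound to an amine nitrogen, 2,3-dihydro-1,4-benzodioxin-2-yl can replace naphthalen-1-yl without a change beyond the scatter. This position therefore accepts a group with one aromatic ring of carbon only and 2 hydrogen-bond acceptors, not only the purely aromatic naphthalen-1-yl. No evidence on the reason is at hand.

Still open, from the compounds shown here alone, is whether cyclohexyl, with no aromatic ring, or a carboxylic acid at this place would keep the number in this range. Also open, going by these compounds, is whether 2,3-dihydro-1,4-benzodioxin-2-yl gives the same result on the chain of compound 3.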